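The compounds below may be only part of what the source reports. "The series", "measured", "known", "first", "only" and "open" are said of these compounds alone.

Compound 1 `N#CC1=C(N)N(c2ccc(S(N)(=O)=O)cc2)C2=C(C(=O)CCC2)C1c1ccccc1` gives 40% in a functional assay on Ehrlich cells (Mus musculus) for antiproliferative activity, read by trypan blue exclusion, with a stated time of 2 h, tested at 100 ug/mL; on this read-out lower numbers stand for a weaker effect and higher numbers for a stronger effect at the one concentration tested. Compound 2 `N#CC1=C(N)N(c2ccc(S(N)(=O)=O)cc2)C2=C(C(=O)CCC2)C1c1ccc(O)cc1` gives 100%, and compound 3 `COc1ccc(C2C(C#N)=C(N)N(c3ccc(S(N)(=O)=O)cc3)C3=C2C(=O)CCC3)cc1` gives 100%; compound 2 thus stands level with compound 3 at the digits shown, the pair sitting together at the top of the three numbers, while compound 1 lies furthest from it. Compound 4 `COc1cc(CC2C(C#N)=C(N)N(c3ccc(S(N)(=O)=O)cc3)C3=C2C(=O)CCC3)ccc1O` has not yet been measured. The change from compound 2 to compound 4 is 4-hydroxy-3-methoxybenzyl in place of 4-hydroxyphenyl on a saturated ring carbon. Among the measured compounds shown here, three measured steps bear on it: a number 60 percentage points higher from compound 1 to compound 2 (beyond the scatter), a number 60 percentage points higher from compound 1 to compound 3 (beyond the scatter), and no change at the digits printed from compound 2 to compound 3 (within the scatter). For the measured compounds named here, both a hydroxy and a methoxy on an aromatic carbon raised the number greatly, and exchanging one for the other changed nothing beyond the scatter; no measured step covers the benzyl part of the change, so a large move is not expected. Compound 4 is therefore expected to give 90%, within 60% to 100%, meaning an expected step of a number 10 percentage points lower from compound 2 to compound 4 (within the scatter).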

Compound 4, a percentage reported as activity, at one concentration (the size of the read-out at that concentration, not a potency): 100%
The estimate for compound 4 lay 10 percentage points below the measured number; the measured number falls inside the stated range.
By their numbers in this assay, from the lowest: compound 1; then compounds 2, 3 and 4 (each within the scatter of the next).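

The group 4-hydroxy-3-methoxybenzyl on this saturated ring carbon in this assay gives no change at the digits printed from compound 2 to compound 4 (within the scatter), gives no change at the digits printed from compound 3 to compound 4 (within the scatter), and gives a number 60 percentage points higher from compound 1 to compound 4 (beyond the scatter). The hydroxy-bearing ring can therefore be carried on a benzyl link without loss here, although compound 2, compound 3 and compound 4 cannot be ranked at this single concentration. Nothing measured here explains this result.

From the compounds shown here alone, it stays open whether plain benzyl, without hydroxy or methoxy, would match phenyl or compound 4. Going by these compounds, the effect of a longer chain, or of an amine or a carboxylic acid on the ring, also remains unknown.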